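The source may report more compounds than this note shows. Statements on the series, on what has been measured and on what is new or still open speak of the compounds shown alone.

Working notes on the series. In a functional assay on CCRF-CEM cells (Homo sapiens) for inhibition, read by sulforhodamine B assay, with a stated time of 48 h (on this read-out higher numbers stand for weaker inhibition of growth and lower numbers for stronger inhibition of growth), compound 1 `COc1ccc(-c2[nH]c3ccccc3c2/C=C(\C#N)S(=O)(=O)c2ccccc2)cc1` gives 1300 nM. Compound 2 `COc1ccc2[nH]c(-c3ccccc3)c(C=C(C#N)C#N)c2c1` gives 3400 nM in this assay. Compound 1 thus holds the lowest of the two numbers shown, and the gap to compound 2 lies beyond the usual scatter; since compound 2 differs from compound 1 in more than one place, nothing is drawn from that gap about any single change.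

Compound 3 `COc1ccc(-c2[nH]c3ccc(OC)cc3c2/C=C(\C#N)S(=O)(=O)c2ccccc2)cc1` has not yet been measured in this assay. It differs from compound 1 in one place: methoxy in place of hydrogen on an aromatic carbon of the shared core. Among the measured compounds shown here, no measured pair isolates this change, so the size of its step is not known from the data.

In the absence of such a pair, the step from compound 1 to compound 3 is expected to be small, at most around a 1.2-fold lower number from compound 1 to compound 3 (0.07 log units; within the scatter) and most likely within the scatter, in either direction. Compound 3 is therefore estimated at 1100 nM in this assay, with a range from 400 nM to 3200 nM.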

Compound 3, concentration for 50% growth inhibition: 1300 nM
For compound 3 the middle estimate is 1.2-fold (0.07 log units) below the measured one; the range from low to high includes it.
By their numbers in this assay, from the lowest: compounds 1 and 3 (each within the scatter of the next); then compound 2.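

Among the compounds shown here, the pair of compound 1 and compound 3 is the first to isolate methoxy in place of hydrogen on an aromatic carbon, and in this assay it gives no change at the digits printed from compound 1 to compound 3 (within the scatter). This position, on a six-membered aromatic ring of carbon only, meta to a fused ring and para to a fused ring, therefore accepts methoxy with no shift in growth inhibition beyond the scatter, so the read-out on this single pair does not respond to this change. No independent measurement bears on why the number stays level between these two compounds.

This single pair does not show whether the flat result is particular to methoxy or holds for this position more generally, for instance with an amine, a carboxylic acid or a longer chain such as butoxy in the same place. It also leaves open whether methoxy on other aromatic carbons of the shared core would behave in the same way in this assay.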